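Replacing the methyl of compound 1 with hydrogen

The source may report more compounds than this note shows. Statements on the series, on what has been measured and on what is new or still open speak of the compounds shown alone.

Values in a functional assay on CCRF-CEM cells (Homo sapiens) for antiproliferative activity, read by MTT assay; a higher number here means a weaker inhibitor, a lower number a stronger inhibitor:
- compound 1 `C/C(=N\Nc1nc2ccccc2o1)c1cnc(C)cn1` gives 620 nM
- compound 2 `C/C(=N\Nc1nc2ccccc2o1)c1cc(C)ncn1` gives 230 nM
- compound 3 `C/C(=N\Nc1nc2ccccc2o1)c1ccc2ccccc2n1` gives 7040 nM

Compound 1, at 620 nM, holds the second highest of the three numbers in this assay. Its number lies beyond the scatter from those of the other two compounds. The next compound is compound 4 `C/C(=N\Nc1nc2ccccc2o1)c1cnccn1`, not yet measured, which has hydrogen in place of methyl on an aromatic carbon.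

Going by the values given here, no measured pair differs in one place only, so the size of this step has no direct precedent. The expectation is a small step, with no change beyond the scatter and no firm direction. The support is thin: compound 1 at 620 nM and compound 2 at 230 nM lie much closer to each other than either does to compound 3 at 7040 nM.

For compound 4 the estimated value is 500 nM, with an expected range of 170 nM to 1500 nM. This estimate means an expected 1.2-fold lower number from compound 1 to compound 4 (0.09 log units; within the scatter).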

Compound 4, half-maximal inhibitory concentration: 430 nM
Compound 4: the middle estimate sits 1.2-fold (0.07 log units) above what was measured, and the stated range covers the measured number.
By their numbers in this assay, from the lowest: compounds 2, 4 and 1 (each within the scatter of the next, the first and the last beyond it); then compound 3.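

In this assay, going by these compounds alone, the first pair that differs in one place gives a 1.4-fold lower number from compound 1 to compound 4 (0.16 log units; within the scatter), so hydrogen in place of methyl on this aromatic carbon, para to a large group, is a step within the scatter. Compound 1 therefore does not depend on its methyl to hold a number in this range, as compound 4 at 430 nM still shows without that carbon. The data on hand offer no explanation for this step and tie it to no property of either group.

From the compounds shown here alone, whether a larger group here, such as an ethyl, a methoxy, an amine or a carboxylic acid, would also stay within the scatter remains open. Also open, going by these compounds, is whether removing the methyl of compound 2 would give a comparable step, since this single pair speaks only for the ring of compound 1.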